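The compounds below may be only part of what the source reports. "The series", "measured", "known", "first", "only" and "open" are said of these compounds alone.

Measured in a functional assay on MT4 cells (Homo sapiens) for antiproliferative activity, read by MTT assay, with a stated time of 96 h; a higher number here means a weaker inhibitor, a lower number a stronger inhibitor:

compound 1, `O=C1NN(c2ccc([N+](=O)[O-])cc2)C(=O)C2(CSC3=C2C(=O)c2ncccc2C3=O)N1`: 5 nM
compound 2, `Cc1ccc(N2NC(=O)NC3(CSC4=C3C(=O)c3ncccc3C4=O)C2=O)cc1`: 100 nM
compound 3, `O=C1C2=C(C(=O)c3ncccc31)C1(CS2)NC(=O)N(c2ccc([N+](=O)[O-])cc2)C1=O`: 8 nM

Compound 1 and compound 2 share a core and differ by methyl in place of nitro on an aromatic carbon; this change brought a 20-fold higher number from compound 1 to compound 2 (1.30 log units; beyond the scatter). Compound 3 carries a different core from compound 1; the difference between the two cores is not broken down here. Its value and that of compound 1 lie within the scatter of each other, while compound 2 sits well apart from both.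

Compound 4, `Cc1ccc(N2C(=O)NC3(CSC4=C3C(=O)c3ncccc3C4=O)C2=O)cc1`, has not yet been measured in this assay. It stands to compound 3 as compound 2 stands to compound 1: the difference is methyl in place of nitro on an aromatic carbon, the same change at the same kind of place, occurring twice in all among these compounds. Within the data shown here, only one measured instance of it exists, so the expectation rests on a single step, because a 20-fold higher number from compound 1 to compound 2 (1.30 log units; beyond the scatter) is all there is to go on. A step of similar size is expected from compound 3 to compound 4, namely a 20-fold higher number from compound 3 to compound 4 (1.30 log units; beyond the scatter). Compound 4 is accordingly expected to give about 160 nM, with a plausible range from 50 nM to 500 nM.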

Compound 4, half-maximal inhibitory concentration: 27 nM
Compound 4: middle estimate off by 5.9-fold (0.77 log units), on the high side, outside the stated range (below it).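

In this assay, methyl in place of nitro brought a 3.4-fold higher number from compound 3 to compound 4 (0.53 log units; beyond the scatter), so the direction seen on the core of compound 1 recurs on the core of compound 3. The size of the step does not carry over from one core to the other: the same change on two cores in this assay, a 20-fold higher number (1.30 log units; beyond the scatter) from compound 1 to compound 2 and a 3.4-fold higher number (0.53 log units; beyond the scatter) from compound 3 to compound 4, 5.9-fold (0.77 log units) apart, beyond the scatter of two such steps With two pairs to compare, this shows that the direction of the change held on both cores while its size differed, but it does not show what in the cores sets the gap, nor whether either the direction or the size would hold on a further core.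

The compounds shown carry only 4-nitrophenyl and 4-methylphenyl, so it remains open how an amine, a carboxylic acid or a nitrile at the same place on the ring would read on each core. From the compounds shown here alone, it is also open whether the gap between the two steps is particular to the exchange of nitro for methyl or would appear with such other groups as well.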